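The compounds below may be only part of what the source reports. "The series", "measured", "known", "first", "only" and "open" are said of these compounds alone.

Of the compounds shown here, three have been measured in a functional assay on HepG2 cells (Homo sapiens) for antiproliferative activity, read by sulforhodamine B assay, with a stated time of 48 h; a lower number here means a stronger inhibitor, a higher number a weaker inhibitor. In that test compound 1 `COc1ccc(-c2ccccc2C(=O)/C=C/c2ccc(Br)cc2)cc1OC` gives 3300 nM, compound 2 `COc1ccc(OC)c(/C=C/C(=O)c2ccccc2-c2ccc(F)cc2)c1` gives 520 nM and compound 3 `COc1ccc(/C=C/C(=O)c2ccccc2-c2cccc(F)c2)cc1` gives 110 nM. Compound 3 therefore has the lowest number of the three, and its gaps to both others lie beyond the scatter, which makes it the strongest inhibitor in this small set. These three differ from one another in more than one place, so no single change can be read from their values.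

Compound 4 `COc1ccc(/C=C/C(=O)c2ccccc2-c2cccnc2)cc1` departs from compound 3 at one place: pyridin-3-yl in place of 3-fluorophenyl on an aromatic carbon, ortho to a large group (pyridin-3-yl in place of 3-fluorophenyl on an aromatic carbon). Going by the values given here, no measured pair shows this swap, so the expectation is a loose one. Because compound 3 stands at 110 nM the number has more room to rise than to fall. A moderate loss in this assay is expected, with a 3.2-fold higher number from compound 3 to compound 4 (0.50 log units; beyond the scatter) as the estimated step. For compound 4 the estimated value is 350 nM, with an expected range from 100 nM to 1300 nM.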

Compound 4, half-maximal inhibitory concentration: 97 nM
For compound 4 the middle estimate is 3.6-fold (0.56 log units) above the measured one; measured number below the stated range.
By their numbers in this assay, from the lowest: compounds 4 and 3 (each within the scatter of the next); then compound 2; then compound 1.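

In this assay, going by these compounds alone, pyridin-3-yl in place of 3-fluorophenyl gives a 1.1-fold lower number from compound 3 to compound 4 (0.05 log units; within the scatter), the first single-place step in this set. At this aromatic carbon, ortho to a large group, the ring that enters carries one hydrogen-bond acceptor and one heavy atom fewer than the ring that leaves, and the read-out does not separate the two. No measurement at hand explains this result.

The compounds shown leave open how far this position accepts other groups, such as pyridin-4-yl, a morpholine ring or a carboxylic acid in the same place. They also leave open whether the same swap would give a step of similar size on the core of compound 1 or compound 2.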